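The source may report more compounds than this note shows. Statements on the series, on what has been measured and on what is new or still open speak of the compounds shown alone.

Series notes, aryl-substituted core. For the measured compounds named here, compound 3 `c1ccc(CCc2ccc3c(NCCCNCc4ccco4)ccnc3c2)cc1` gives 4200 nM in a physicochemical assay for solubility, with a stated time of 18 h, at pH 7.4 (on this read-out higher numbers stand for higher solubility and lower numbers for lower solubility), the lowest of the three numbers so far. Compound 1 `c1ccc(-c2ccc3c(NCCCNCc4ccco4)ccnc3c2)cc1` gives 32000 nM in this assay, and compound 2 `CC(C)(C)c1ccc(Oc2ccc3c(NCCCNCc4ccco4)ccnc3c2)cc1` gives 14500 nM in this assay. Going by the values given here, the one single-site step measured so far is a 7.6-fold lower number from compound 1 to compound 3 (0.88 log units; beyond the scatter); between compound 2 and compound 3 no step is defined, the two values simply show compound 3 lower.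

Compound 4 `COc1cccc(Oc2ccc3c(NCCCNCc4ccco4)ccnc3c2)c1` is the next member. It differs from compound 3 at one place: 3-methoxyphenoxy in place of phenethyl on an aromatic carbon. Compound 3 to compound 4 is not a reversal of the measured step, so that step is only a loose guide; it shows that exchanging the group at this aromatic carbon moves the read-out by a modest amount, and compound 2, also an aryl ether at this position, sits well above compound 3. A rise beyond the scatter is therefore expected, by a 4.8-fold higher number from compound 3 to compound 4 (0.68 log units; beyond the scatter). Compound 4 is estimated at 20000 nM, with a range from 7000 nM to 60000 nM.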

Compound 4, solubility: 14500 nM
For compound 4 the middle estimate is 1.4-fold (0.14 log units) above the measured one; the measured number falls inside the stated range.
By their numbers in this assay, from the lowest: compound 3; then compounds 2 and 4 (each within the scatter of the next); then compound 1.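

In this assay the exchange of phenethyl for 3-methoxyphenoxy gives a 3.5-fold higher number from compound 3 to compound 4 (0.54 log units; beyond the scatter) and the exchange of phenyl for 3-methoxyphenoxy gives a 2.2-fold lower number from compound 1 to compound 4 (0.34 log units; beyond the scatter) so this aromatic carbon now has three groups compared directly, with the aryl ether separated from both others beyond the scatter. Within the aryl ethers, 3-methoxyphenyl in place of 4-(tert-butyl)phenyl on the oxygen gives no change at the digits printed from compound 2 to compound 4 (within the scatter) and this exchange leaves the read-out within the scatter, something the earlier compounds could not show. No measurement here accounts for these differences.

Still open, going by these compounds, is how an amine or a carboxylic acid on the aryl ring of the ether would move the number. Also open, on these data alone, is where a longer chain than phenethyl at this aromatic carbon would fall.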